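The compounds below may be only part of what the source reports. "The series", "measured", "known", "first", "only" and "open" are said of these compounds alone.

In a functional assay on OVCAR-3 cells (Homo sapiens) for cytotoxicity, read by sulforhodamine B assay (a lower number here means that less compound is tolerated, a higher number that more compound is tolerated), compound 1 `CC1=CC[C@@H]([C@@](C)(O)CCCC(C)(C)NC(=S)N/N=C\c2ccc(C)cc2)CC1` gives 45300 nM and compound 2 `COc1ccc(/C=N\NC(=S)NC(C)(C)CCC[C@](C)(O)[C@@H]2CC=C(C)CC2)cc1` gives 46200 nM, so compound 2 sits level with its nearest neighbour. Methoxy in place of methyl gave a 1.0-fold higher number from compound 1 to compound 2 (0.01 log units; within the scatter). Compound 3 `CC1=CC[C@@H]([C@@](C)(O)CCCC(C)(C)NC(=S)N/N=C\c2ccc(N(C)C)cc2)CC1` reads > 100000 nM, which is a limit of the assay and not a number. Dimethylamino in place of methoxy gave an at least 2.1-fold higher number from compound 2 to compound 3 (0.33 log units; beyond the scatter), and in place of methyl it gave an at least 2.2-fold higher number from compound 1 to compound 3 (0.34 log units; beyond the scatter).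

Compound 4 `CC1=CC[C@@H]([C@@](C)(O)CCCC(C)(C)NC(=S)N/N=C\c2ccc([N+](=O)[O-])cc2)CC1` carries nitro in place of methoxy on an aromatic carbon, para to a large group: nitro in place of methoxy on an aromatic carbon. All three measured steps change this same group, and only the two resting on the limit exceed the scatter. No step beyond the scatter is therefore expected in this assay, and the expected change is a 1.2-fold lower number from compound 2 to compound 4 (0.06 log units; within the scatter). Compound 4 is estimated at 40000 nM, with an expected range of 15000 nM to 100000 nM.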

Compound 4, concentration lethal to 50% of the cells: > 100000 nM
Compound 4 ended at the assay's limit (the forecaster's own chance of this, stated with the estimate: 15%); at least 2.5-fold (0.39 log units) between middle value and limit.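

Compound 4 shows that dimethylamino is not alone at this place on the ring: nitro also stands beyond the scatter from methoxy (an at least 2.1-fold higher number from compound 2 to compound 4 (0.33 log units; beyond the scatter)) and from methyl (an at least 2.2-fold higher number from compound 1 to compound 4 (0.34 log units; beyond the scatter)). Both steps are only minimum sizes, since the reading of compound 4 is a limit and not a number: the limit of > 100000 nM in this assay, at which 2 of the 4 values shown sit. The step from compound 3 to compound 4 cannot be read, so these two groups cannot be put in order.

On these data alone, the true sizes of both steps stay open. So does whether a carboxylic acid or a primary amine at this place would also separate from methoxy in this assay.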